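Replacing a cyclopropyl with a methoxymethyl on the amine chain

A few compounds are considered here, and "the series" means these few. Any claim that something is new, unique, unknown or untested is made for them only; others in the source may bear on it.

Measured so far:
compound 1, `COc1cccc(CNCc2c(-c3nnc(SC(C)C)n3-c3ccccc3)n(C)c3ccccc23)c1`, 6.27
compound 2, `CC(C)Sc1nnc(-c2c(CNCC3CC3)c3cc(F)ccc3n2C)n1-c1ccccc1`, 5.4
compound 3, `CC(C)Sc1nnc(-c2c(CNCC3CC3)c3ccccc3n2C)n1-c1ccccc1`, 5.24

In a physicochemical assay for lipophilicity (on this read-out lower numbers stand for lower lipophilicity and higher numbers for higher lipophilicity), compound 3 stands lowest of the three numbers; compound 2 lies nearest, within the scatter, and compound 1 lies furthest. The step of a number 0.16 log units lower from compound 2 to compound 3 (within the scatter) is within the scatter, while the step of a number 1.03 log units lower from compound 1 to compound 3 (beyond the scatter) is beyond it.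

Compound 4, `COCCNCc1c(-c2nnc(SC(C)C)n2-c2ccccc2)n(C)c2ccccc12`, has not yet been measured. It differs from compound 3 as follows: methoxymethyl in place of cyclopropyl on a saturated chain carbon bound to an amine nitrogen. The change sits at the same place as the change from compound 1 to compound 3, so that step bears on it, though it exchanged a different group and is not a direct match. Among the compounds with values here, no measured pair exchanges cyclopropyl for methoxymethyl. Since the group that leaves carries no acceptor and the one that enters carries one, a downward step in this assay is expected, smaller than the step from compound 1 to compound 3. The estimate for compound 4 is 4.5, between 4 and 5, which would mean an expected step of a number 0.74 log units lower from compound 3 to compound 4 (beyond the scatter).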

Compound 4, partition coefficient: 4.36
Compound 4: middle estimate off by 0.14 log units, on the high side; low and high end bracket the measured number.
By their numbers in this assay, from the lowest: compound 4; then compounds 3 and 2 (each within the scatter of the next); then compound 1.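

In this assay, this place on a saturated chain carbon bound to an amine nitrogen proves sensitive even when 3 heavy atoms leave and 3 enter: methoxymethyl, with no ring and 1 hydrogen-bond acceptor, in place of cyclopropyl gives a number 0.88 log units lower from compound 3 to compound 4 (beyond the scatter) and thus a clear change without any change in heavy-atom count. Together with the exchange of 3-methoxyphenyl for methoxymethyl, a number 1.91 log units lower from compound 1 to compound 4 (beyond the scatter), the position now spans a wider range of values than the earlier compounds showed. Nothing available accounts for the size of these steps.

The compounds shown leave open how much of the step from cyclopropyl goes with the loss of the ring and how much with the oxygen, which an open propyl chain or an oxetanyl ring could separate. They also leave open whether methoxymethyl gives a similar step on the fluoro-bearing core of compound 2.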